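The source may hold more compounds than are shown below. What is called first, only, known or untested is meant among the compounds shown, and "the series" means these compounds.

Compound 1 `Cc1cc(C)cc(S(=O)(=O)c2c(C(=O)NCC(=O)NCCn3c(C)cnc3[N+](=O)[O-])[nH]c3ccc(Cl)cc23)c1`: 24500 nM
Compound 2 `Cc1cc(C)cc(S(=O)(=O)c2c(C(=O)NCC(=O)NCc3ccncn3)[nH]c3ccc(Cl)cc23)c1`: a limit only, > 48800 nM
Compound 3 `Cc1cc(C)cc(S(=O)(=O)c2c(C(=O)NCC(=O)NC(C)c3ccccc3F)[nH]c3ccc(Cl)cc23)c1`: 23000 nM

In an ADME assay on MT4 cells (Homo sapiens) for cytotoxicity, read by MTT assay (on this read-out lower numbers stand for higher toxicity in this test and higher numbers for lower toxicity in this test), compound 1 gives 24500 nM and compound 3 gives 23000 nM. For compound 2 the result is only a limit, > 48800 nM, so no exact number is known (the limit of > 48800 nM in this assay, at which 1 of the 3 values shown sits). Compound 4 `Cc1cc(C)cc(S(=O)(=O)c2c(C(=O)Nc3cc(C#N)ccn3)[nH]c3ccc(Cl)cc23)c1` has not yet been measured. Compared with compound 2 it carries a group of 8 heavy atoms (6 carbon, 2 nitrogen; one six-membered aromatic ring with 1 hetero atom) in place of a group of 11 heavy atoms (7 carbon, 3 nitrogen, 1 oxygen; one six-membered aromatic ring with 2 hetero atoms), on an amide-type nitrogen. Within the data shown here, two measured steps touch compound 2: an at least 1.9-fold higher number from compound 1 to compound 2 (0.29 log units; that floor lies within the scatter) and an at least 2.1-fold lower number from compound 2 to compound 3 (0.32 log units; beyond the scatter). Both begin or end at the limit, so their sizes are only floors. Among the measured compounds shown here, the change to compound 4 is larger than either of those, and no measured step resembles it closely. Compound 4 is therefore expected at about 30000 nM, within 10000 nM to 60000 nM. That expected value corresponds to a step of an at least 1.6-fold lower number from compound 2 to compound 4 (0.21 log units; that floor lies within the scatter).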

Compound 4, half-maximal cytotoxic concentration: > 53700 nM
Compound 4 gave a limit, no number; the forecaster's own chance of this, stated with the estimate: 40%; middle value at least 1.7-fold (0.25 log units) from the limit.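

Compound 2 and compound 4 each gave only a limit, not a number, and the step between them cannot be read. From the compounds shown here alone, whether 4-cyanopyridin-2-yl on the amide-type nitrogen raises or lowers the number, and by how much, stays open.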